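Hydroxyphenyl position on the shared core, one ring change

A few compounds are considered here, and "the series" means these few. Any claim that something is new, unique, unknown or untested is made for them only; others in the source may bear on it.

Measured so far:
compound 1 `Oc1cccc(-c2ccc3c(-c4cncnc4)c(O)ccc3c2)c1` — 41%
compound 2 `Oc1cccc(-c2ccc3c(-c4ccc5[nH]ccc5c4)c(O)ccc3c2)c1` — 87%
compound 3 `Cn1cc(-c2c(O)ccc3cc(-c4cccc(O)c4)ccc23)cn1` — 71%

In an assay for binding affinity to 17-beta-hydroxysteroid dehydrogenase type 1 (Homo sapiens), read by scintillation counting, with a stated time of 10 min, tested at 1 uM (a lower number here means less inhibition, a higher number more inhibition at the concentration tested (going by the name of the read-out)), compound 1 gives the lowest of the three numbers. The nearest is compound 3, reached by a number 30 percentage points higher from compound 1 to compound 3 (beyond the scatter), and the furthest is compound 2, reached by a number 46 percentage points higher from compound 1 to compound 2 (beyond the scatter); the gap between those two, a number 16 percentage points lower from compound 2 to compound 3 (beyond the scatter), is also beyond the scatter. All three measured steps vary the heteroaryl on the core and leave the 3-hydroxyphenyl untouched.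

Compound 4 `Oc1ccc(-c2ccc3c(-c4cncnc4)c(O)ccc3c2)cc1` differs from compound 1 in the other direction: 4-hydroxyphenyl in place of 3-hydroxyphenyl on an aromatic carbon. For the measured compounds named here, no measured step bears on this change, so the measured series gives no direction for it. The expectation is therefore a step near zero, within the scatter, with a wide range to either side: a number 1 percentage points lower from compound 1 to compound 4 (within the scatter). Compound 4 is estimated at 40%, between 15% and 65%.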

Compound 4, a percentage reported as inhibition, at one concentration (the size of the read-out at that concentration, not a potency): 35%
Compound 4: the middle estimate sits 5 percentage points above what was measured; measured number inside the range.
By their numbers in this assay, from the lowest: compounds 4 and 1 (each within the scatter of the next); then compound 3; then compound 2.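

In this assay, with pyrimidin-5-yl held on the shared core, 4-hydroxyphenyl in place of 3-hydroxyphenyl gives a number 6 percentage points lower from compound 1 to compound 4 (within the scatter), so this position accepts either hydroxyphenyl with no difference that can be told from the scatter. For the compounds shown here, the earlier steps varied only the heteroaryl and reached as far as a number 46 percentage points higher from compound 1 to compound 2 (beyond the scatter), whereas this is the only reading on the hydroxyphenyl position, and it puts the two compounds within the scatter of each other. No available evidence bears on this result.

As far as these compounds go, whether the same holds with 1H-indol-5-yl or 1-methyl-1H-pyrazol-4-yl on the core remains open, as this pair carries pyrimidin-5-yl alone. Also open, from the compounds shown here alone, is what a methoxy group, an amine or a carboxylic acid would do in place of the hydroxyl on this phenyl ring.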